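Cyclopropyl-bearing fused cores: isopropyl to methyl on compound 3

A few compounds are considered here, and "the series" means these few. Any claim that something is new, unique, unknown or untested is made for them only; others in the source may bear on it.

Measured so far in an in vivo functional assay on the whole organism for inhibition of 3-hydroxy-3-methylglutaryl-coenzyme A reductase (Rattus norvegicus), at a dose of 2 mg/kg by the oral route; on this read-out higher numbers stand for a stronger effect at the one dose given and lower numbers for a weaker effect:
compound 1 `Cc1nn(C)c2nc(C3CC3)c(/C=C/[C@@H](O)C[C@@H](O)CC(=O)O)c(-c3ccc(F)cc3)c12` gives 74.3%
compound 2 `CC(C)c1nc2c(c(C3CC3)nn2C)c(-c2ccc(F)cc2)c1/C=C/[C@@H](O)C[C@@H](O)CC(=O)O` gives 71.3%
compound 3 `CC(C)c1cc2nc(C3CC3)c(/C=C/[C@@H](O)C[C@@H](O)CC(=O)O)c(-c3ccc(F)cc3)n2n1` gives -19.4%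

Compound 1 and compound 2 share a core that differs from the core of compound 3, and both sit high on this read-out; their two values lie within the scatter of each other. Compound 3 stands lowest of the three numbers, a gap beyond the scatter from compound 2 and from compound 1, so the core of compound 3 is the only one here that shows no inhibition.

Compound 4 `Cc1cc2nc(C3CC3)c(/C=C/[C@@H](O)C[C@@H](O)CC(=O)O)c(-c3ccc(F)cc3)n2n1` keeps the core of compound 3 and changes one group: methyl in place of isopropyl on an aromatic carbon. Within the data shown here, no pair of measured compounds differs in exactly this way, so no measured step can be carried over. Compound 1 and compound 2 carry methyl and isopropyl on a different core and at different places, and say nothing direct about this change.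

Given that compound 3 gives -19.4%, the step of a number 19.4 percentage points higher from compound 3 to compound 4 (beyond the scatter) is expected to be small, in either direction, and not beyond the scatter. Compound 4 is therefore estimated at 0%, with a range from -25% to 30%.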

Compound 4, a percentage reported as inhibition, in the whole organism at one dose (the size of the read-out at that dose, not a potency): 6.5%
Beside the measured number, compound 4's estimate is 6.5 percentage points below it; measured number inside the range.
By their numbers in this assay, from the lowest: compound 3; then compound 4; then compounds 2 and 1 (each within the scatter of the next).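

Among these compounds, on the core of compound 3, methyl in place of isopropyl on an aromatic carbon gives the first measured step at this position in this assay: a number 25.9 percentage points higher from compound 3 to compound 4 (beyond the scatter). The change therefore registers on this read-out, yet compound 4 gives only 6.5%, so this swap alone does not bring a strong effect at the one dose given. Nothing measured here bears on why the number moves.

With only isopropyl and methyl shown, this position rests on two points, and how an ethyl chain or an amine on the same carbon would read remains open. Among the compounds shown here, whether the step would carry over to the core of compound 1 also remains open, since no pair on that core differs in this way.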